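A few compounds are considered here, and "the series" means these few. Any claim that something is new, unique, unknown or untested is made for them only; others in the source may bear on it.

Compounds measured in a functional assay for inhibition of nuclear factor NF-kappa-B complex (Homo sapiens); on this read-out lower numbers stand for stronger inhibition and higher numbers for weaker inhibition:
compound 1, `COc1ccc2c(c1)OC(c1cc(OC)c(OC)c(OC)c1)C(C(=O)N(C)OC)=C2`: 11700 nM
compound 2, `COC(=O)C1=Cc2ccc(OC)cc2OC1c1cc(OC)c(OC)c(OC)c1`: 13800 nM
compound 3, `CCCCNC(=O)C1=Cc2ccc(OC)cc2OC1c1cc(OC)c(OC)c(OC)c1`: 25500 nM

Compound 3 sits at the highest number of the three. Its gap to compound 2 is within the scatter, while against compound 1 the step of a 2.2-fold higher number from compound 1 to compound 3 (0.34 log units; beyond the scatter) is modest but beyond it. Compound 4, `COc1ccc2c(c1)OC(c1cc(OC)c(OC)c(OC)c1)C(C(=O)N(C)C)=C2`, differs from compound 3 by dimethylamino in place of butylamino on a carbonyl carbon. For the measured compounds named here, two measured steps bear on this change at the carbonyl carbon: a 2.2-fold higher number from compound 1 to compound 3 (0.34 log units; beyond the scatter) and a 1.8-fold higher number from compound 2 to compound 3 (0.27 log units; within the scatter). Both replaced a small group with butylamino and both raised the number, the first beyond the scatter. Compound 4 reverses that direction with a small dimethylamino group, so a modest lowering of the number is expected, a 1.8-fold lower number from compound 3 to compound 4 (0.26 log units; within the scatter), bringing it near compound 1. Compound 4 is estimated at 14000 nM, with a range from 6000 nM to 35000 nM.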

Compound 4, half-maximal inhibitory concentration: > 50000 nM
Compound 4 ended at the assay's limit (the forecaster's own chance of this, stated with the estimate: 10%); middle value at least 3.5-fold (0.55 log units) away from the limit.
By their numbers in this assay, from the lowest: compounds 1, 2 and 3 (each within the scatter of the next, the first and the last beyond it). At a limit, above all of these: compound 4.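

In this assay compound 4 reads as a limit, not a number: the limit of > 50000 nM in this assay, at which 1 of the 4 values shown sits. Methyl in place of methoxy on the amide-type nitrogen gives an at least 4.2-fold higher number from compound 1 to compound 4 (0.63 log units; beyond the scatter), and dimethylamino in place of methoxy on the carbonyl carbon gives an at least 3.6-fold higher number from compound 2 to compound 4 (0.55 log units; beyond the scatter), so a small group at this carbonyl carbon does not by itself keep the number low. The comparison with butylamino settles less, with an at least 1.9-fold higher number from compound 3 to compound 4 (0.29 log units; that floor lies within the scatter) as a floor only.

From the compounds shown here alone, the true value of compound 4 stays open. Also open, going by these compounds, is where methylamino, a longer chain on the amide nitrogen or a carboxylic acid at this carbonyl carbon would fall.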